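The source may hold more compounds than are shown below. What is called first, only, known or untested is meant among the compounds shown, and "the series" means these compounds.

Of the compounds shown here, two of one series have been measured so far. Compound 1 `CNC(=O)c1cccc(NC(=O)N2CCC(Oc3ccccc3)CC2)c1` and compound 2 `O=C(Nc1ccccc1)N1CCC(Oc2ccccc2Cl)CC1` share a core in which a phenoxy-bearing piperidine is linked through a urea to an aniline. In an assay on isolated protein for inhibition of acyl-CoA desaturase 1 (Mus musculus) (on this read-out higher numbers stand for weaker inhibition and lower numbers for stronger inhibition), compound 1 gives 370 nM. In this assay compound 2 gives 590 nM, a number that sits close to that of compound 1, the gap between the two lying within the usual scatter of repeated measurements, so neither can be called the stronger inhibitor on these data.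

Compound 3 `CC(C)(C)NC(=O)c1cccc(NC(=O)N2CCC(Oc3ccccc3Cl)CC2)c1` is not yet measured. It differs from compound 2 in one place: (tert-butyl)carbamoyl in place of hydrogen on an aromatic carbon. Among the compounds with values here, no measured pair shows this change on its own, so its effect can only be guessed. Compound 3 is expected to land at roughly 300 nM, within a range of 80 nM to 1200 nM, which means an estimated step of a 2.0-fold lower number from compound 2 to compound 3 (0.29 log units; within the scatter) of modest size toward stronger inhibition, though the wide range admits a step in either direction.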

Compound 3, half-maximal inhibitory concentration: > 10000 nM
Compound 3 gave a limit, no number; the forecaster's own chance of this, stated with the estimate: 5%; at least 33-fold (1.52 log units) between middle value and limit.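

Placing (tert-butyl)carbamoyl on this aromatic carbon, meta to a large group, is the first single change seen in the series, and in this assay it gives an at least 16-fold higher number from compound 2 to compound 3 (1.22 log units; beyond the scatter). The result for compound 3 is a limit of the assay, not an exact number: the limit of > 10000 nM in this assay, at which 1 of the 3 values shown sits.

Even so, it shows that this position is sensitive to what it carries: one added group can weaken inhibition well beyond the scatter, which compounds 1 and 2, differing in more than one place, could not reveal.

The compounds shown do not tell whether the loss comes from the tert-butyl part or the carbamoyl part of the new group. Going by these compounds, it also stays open whether a carboxylic acid, an amine or a nitrile on that same aromatic carbon would keep inhibition.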